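Carbamoyl in place of cyano: compound 3 in cytotoxicity

The compounds below may be only part of what the source reports. "The series", "measured", "known", "first", "only" and "open" are said of these compounds alone.

Compound 1 `O=C(NO)c1cc2ccn(Cc3ccc(F)cc3)c2cn1`: 159000 nM
Compound 2 `N#Cc1ccc(Cn2ccc3cc(C(=O)NO)ncc32)cc1`: > 10000 nM, a limit

These working notes follow the series in an ADME assay on CEM-SS cells (Homo sapiens) for cytotoxicity, read by XTT assay; a higher number here means that more compound is tolerated, a lower number that less compound is tolerated. Compound 2 stands at > 10000 nM, which is a limit and not a number. The evidence so far includes (the limit of > 10000 nM in this assay, at which 1 of the 2 values shown sits). Within the data shown here, compound 1 gives the only true number, 159000 nM.

The next compound is compound 3 `NC(=O)c1ccc(Cn2ccc3cc(C(=O)NO)ncc32)cc1`. It carries carbamoyl in place of cyano on an aromatic carbon, on a six-membered aromatic ring of carbon only, para to a large group: carbamoyl in place of cyano on an aromatic carbon.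

Among the measured compounds shown here, one measured step bears on this change, a step that the limit leaves unreadable from compound 1 to compound 2. It is also a replacement on an aromatic carbon, but its size cannot be read, so it gives no size or direction to carry over to the new step in this assay. For the measured compounds named here, the sole numerical anchor is compound 1 at 159000 nM, so compound 3 is placed on the same scale. There is a good chance that only a limit is reported for compound 3. The estimated step is a step that the limit leaves unreadable from compound 2 to compound 3. For compound 3 the expected value is 60000 nM, with an estimated range of 10000 nM to 200000 nM.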

Compound 3, half-maximal cytotoxic concentration: > 10000 nM
Compound 3: no number, only a limit; the forecaster's own chance of this, stated with the estimate: 60%; the middle value does not contradict the limit.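

In this assay compound 3 gives > 10000 nM as a limit and not a number. Among these compounds, no step to compound 3 can be read, neither from compound 2 nor from compound 1, because limits stand in place of numbers: the limit of > 10000 nM in this assay, at which 2 of the 3 values shown sit.

Open, as far as these compounds go, is how far compound 2 and compound 3 lie from compound 1, from each other, and in which direction.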